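Replacing methoxy with a carbamoyl on a shared core

The source may report more compounds than this note shows. Statements on the series, on what has been measured and on what is new or still open speak of the compounds shown alone.

Three compounds have been measured in an ADME assay on HEK293 cells for agonist activity at Toll-like receptor 8 (Homo sapiens), read by a luciferase reporter, with a stated time of 6 h; a higher number here means that more compound is needed for the effect, a lower number that less compound is needed:

compound 1 `CCCCNc1nc(N)nc2ccc(OC)cc12` gives 1.8 uM
compound 2 `CCCCNc1nc(N)nc2ccc(C(C)O)cc12` gives 5.8 uM
compound 3 `CCCCNc1nc(N)nc2cccc(OC)c12` gives 0.1 uM

Compound 3 stands lowest of the three numbers; the next nearest is compound 1, and compound 2 lies furthest away, both of them beyond the scatter. The unmeasured compound 4 `CCCCNc1nc(N)nc2cccc(C(=O)N(C)C(C)C)c12` differs from compound 3 in one place: isopropyl(methyl)carbamoyl in place of methoxy on an aromatic carbon.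

Among the compounds with values here, only one measured step bears on this change, and only loosely. Between compound 1 and compound 2 the methoxy also left an aromatic carbon, replaced there by a 1-hydroxyethyl, and the result was a 3.2-fold higher number from compound 1 to compound 2 (0.51 log units; beyond the scatter). That step sits on a different carbon of the shared core and brings in a smaller group than the isopropyl(methyl)carbamoyl entering here, so it is a weak guide. Within the data shown here, still, it is the only evidence, and it points to a higher number when methoxy gives way to a bulkier group. Compound 4 is therefore expected to give a higher number than compound 3 in this assay, an expected step of a 6.0-fold higher number from compound 3 to compound 4 (0.78 log units; beyond the scatter), with wide uncertainty because the entering group is unlike anything yet measured. The estimate for compound 4 is 0.6 uM, between 0.1 uM and 4 uM.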

Compound 4, minimum effective concentration: > 25 uM
Compound 4: a limit, no number; the forecaster's own chance of this, stated with the estimate: 5%; middle value at least 41-fold (1.61 log units) away from the limit.
By their numbers in this assay, from the lowest: compound 3; then compound 1; then compound 2. At a limit, above all of these: compound 4.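

In this assay compound 4 gives > 25 uM, which is a limit of the assay and not a number: the limit of > 25 uM in this assay, at which 1 of the 4 values shown sits.

Within the data shown here, on this aromatic carbon, ortho to a fused ring and meta to a fused ring, isopropyl(methyl)carbamoyl in place of methoxy gives an at least 250-fold higher number from compound 3 to compound 4 (2.39 log units; beyond the scatter), a step printed as large, whereas the only earlier step, a 3.2-fold higher number from compound 1 to compound 2 (0.51 log units; beyond the scatter), was modest and concerned another carbon and another entering group. The earlier compounds shown here therefore gave no sign that a single exchange could carry a compound from the lowest number of the set to the limit of the assay, and this one exchange at this position does exactly that.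

What the compounds shown leave open is how far the true number of compound 4 lies past that limit, and which part of the entering group goes with the change: the carbonyl, the isopropyl or the methyl on the amide nitrogen. A plain carbamoyl, a dimethylcarbamoyl, an ethoxy or a longer ether chain on the same carbon would begin to separate these parts.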